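Urea in Place of Amide on a Pyrazole Series

The compounds below may be only part of what the source reports. "The series", "measured", "known", "first", "only" and "open" are said of these compounds alone.

The study compares three compounds in a functional assay on RPMI-8226 cells (Homo sapiens) for inhibition, read by sulforhodamine B assay, with a stated time of 48 h; on this read-out higher numbers stand for weaker inhibition of growth and lower numbers for stronger inhibition of growth. Compound 1 `COc1cc(-c2nn(-c3cccc(NC(=O)Nc4cc(C(F)(F)F)cc(C(F)(F)F)c4)c3)cc2-c2ccncc2)ccc1Cl` gives 307 nM. Compound 2 `COc1cc(-c2nn(-c3cccc(NC(=O)c4cccc(C(F)(F)F)c4)c3)cc2-c2ccncc2)ccc1Cl` gives 1570 nM, the highest of the three numbers. Compound 3 `O=C(Nc1cccc(-n2cc(-c3ccncc3)c(-c3ccc(Cl)c(O)c3)n2)c1)Nc1ccc(Cl)c(Cl)c1` gives 1030 nM, which lies within the scatter of compound 2, so no order between these two can be drawn, whereas the gap from compound 2 to compound 1 lies beyond it. Compound 4 `COc1cc(-c2nn(-c3cccc(NC(=O)Nc4cccc(C(F)(F)F)c4)c3)cc2-c2ccncc2)ccc1Cl` differs from compound 2 by (3-(trifluoromethyl)phenyl)amino in place of 3-(trifluoromethyl)phenyl on a carbonyl carbon. Since compound 1, the one urea that shares the methoxy and chloro pattern, gives 307 nM, the author expects a step toward stronger inhibition from compound 2 to compound 4 a 3.1-fold lower number from compound 2 to compound 4 (0.50 log units; beyond the scatter), beyond the scatter. Compound 4 is estimated at 500 nM, between 200 nM and 1300 nM.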

Compound 4, concentration for 50% growth inhibition: 340 nM
The estimate for compound 4 lay 1.5-fold (0.17 log units) above the measured number; the measured number falls inside the stated range.
By their numbers in this assay, from the lowest: compounds 1 and 4 (each within the scatter of the next); then compounds 3 and 2 (each within the scatter of the next).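

In this assay, going by these compounds alone, the (3-(trifluoromethyl)phenyl)amino group in place of 3-(trifluoromethyl)phenyl on a carbonyl carbon gives a 4.6-fold lower number from compound 2 to compound 4 (0.66 log units; beyond the scatter) and so offers the first single-place reading of urea against amide. Hydrogen in place of trifluoromethyl on an aromatic carbon gives a 1.1-fold higher number from compound 1 to compound 4 (0.04 log units; within the scatter) and thus no readable change. No measurement at hand accounts for either step.

Going by these compounds, whether a methylene or an ether oxygen in place of that amino nitrogen would give a similar step stays open. So does the outcome of a carboxylic acid or an amine on the same aromatic ring.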